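Predicting Clearance After a Chlorophenyl-to-Methoxyphenyl Swap

A few compounds are considered here, and "the series" means these few. Any claim that something is new, unique, unknown or untested is made for them only; others in the source may bear on it.

Three sulfone-bearing compounds on a shared bicyclic core have been measured in an ADME assay on microsomes from liver (Homo sapiens) for metabolic stability, tested at 2.5 uM; on this read-out higher numbers stand for fast clearance and lower numbers for slow clearance. Compound 3 `O=S(=O)(c1ccc(F)cc1)c1cnc2c(F)cccc2c1-c1cccc(Cl)c1` gives 1.21 mL/min, and compound 1 `COc1ccc(-c2c(S(=O)(=O)c3ccc(F)cc3)cnc3c(F)cccc23)cc1`, which differs from it by 4-methoxyphenyl in place of 3-chlorophenyl on an aromatic carbon, gives 2.41 mL/min in this assay; the step is a 2.0-fold higher number from compound 3 to compound 1 (0.30 log units; within the scatter). Compound 2 `O=S(=O)(c1cc(Cl)cc(Cl)c1)c1cnc2cc(F)ccc2c1-c1cccc(Cl)c1` gives 0.93 mL/min in this assay; how its core differs from that of compound 3 is not broken down here, and the two values lie within the scatter of one another. Compound 4 `COc1ccc(-c2c(S(=O)(=O)c3cc(Cl)cc(Cl)c3)cnc3cc(F)ccc23)cc1` is not yet measured and differs from compound 2 by 4-methoxyphenyl in place of 3-chlorophenyl on an aromatic carbon, the same change as that from compound 3 to compound 1, at the same place. Compound 4 is therefore expected to show a step of a 1.9-fold higher number from compound 2 to compound 4 (0.29 log units; within the scatter) in this assay, resting on the step of a 2.0-fold higher number from compound 3 to compound 1 (0.30 log units; within the scatter). The estimate for compound 4 is 1.8 mL/min, spanning 0.9 mL/min to 3.6 mL/min.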

Compound 4, intrinsic clearance in a liver preparation (reported as CLH), per the amount of preparation that the assay uses: 1 mL/min
Compound 4: the middle estimate sits 1.8-fold (0.26 log units) above what was measured; the range from low to high includes it.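

In this assay, 4-methoxyphenyl in place of 3-chlorophenyl gives a 1.1-fold higher number from compound 2 to compound 4 (0.03 log units; within the scatter), and the two steps for this change do not differ beyond the scatter: the same change on two cores in this assay, a 2.0-fold higher number (0.30 log units; within the scatter) from compound 3 to compound 1 and a 1.1-fold higher number (0.03 log units; within the scatter) from compound 2 to compound 4, 1.9-fold (0.27 log units) apart, within the scatter of two such steps. The change can therefore be carried from the core of compound 3 to the core of compound 2 without any measurable difference in its step. Both steps lie within the scatter, however, so they do not show that the change has a real effect on clearance, and two cores cannot show how it would behave across the wider series.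

The compounds shown leave open what an amine or a carboxylic acid would give at this place. They also leave open whether any such group would produce a step beyond the scatter.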